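Methyl for Trifluoromethyl on a Pair Stalled at the Limit

This account rests on a few compounds, and the source may have more. Where it says the series, first, only, none or still open, it means among the compounds named here.

Compound 1, `O=C1NC(=O)/C(=C\c2ccc(OCC(=O)N3N=C(c4ccc(F)cc4)CC3c3ccccc3Cl)cc2)S1`: in an assay on cells for inhibition of histone deacetylase 8 (Homo sapiens), read by fluorescence, with a stated time of 30 min (a higher number here means a weaker inhibitor, a lower number a stronger inhibitor), compound 1 gives > 50000 nM, which is a limit of the assay rather than a number.
Compound 2, `O=C1NC(=O)/C(=C\c2ccc(OCC(=O)N3N=C(c4ccc(F)cc4)CC3c3ccc(C(F)(F)F)cc3)cc2)S1`: in this assay compound 2 gives > 50000 nM, likewise a limit of the assay.

Compound 2 therefore stands nowhere on a scale of numbers: it sits at the limit of this assay, as does compound 1. Within the data shown here, the one measured step, a step that the two limits leave unreadable from compound 1 to compound 2, has no readable size because the limit of > 50000 nM in this assay, at which 2 of the 2 values shown sit, covers both of its ends.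

Compound 3, `Cc1ccc(C2CC(c3ccc(F)cc3)=NN2C(=O)COc2ccc(/C=C3/SC(=O)NC3=O)cc2)cc1`, differs from compound 2 by methyl in place of trifluoromethyl on an aromatic carbon. Among the measured compounds shown here, no measured step bears on this change, since the only step, a step that the two limits leave unreadable from compound 1 to compound 2, offers no direction or size to carry over. With both measured neighbours at the limit, nothing suggests that compound 3 would move into the measurable range, and the expectation is a further limit in this assay. Compound 3 is thus expected to show about 50000 nM, within a range from 20000 nM to 100000 nM. The step this estimate implies, a number no higher from compound 2 to compound 3 (the limit leaves the size open), is expected to be no larger than the scatter.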

Compound 3, half-maximal inhibitory concentration: > 50000 nM
Compound 3 gave a limit, no number; the forecaster's own chance of this, stated with the estimate: 85%; the middle value lies on the limit itself.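

The steps linking compound 1, compound 2 and compound 3 cannot be read in this assay, because all three compounds stand at the same limit of the assay rather than at numbers: the limit of > 50000 nM in this assay, at which 3 of the 3 values shown sit.

The compounds shown leave open whether any change on the shared core gives a number in this assay, and how 2-chlorophenyl, 4-(trifluoromethyl)phenyl and 4-methylphenyl rank against one another.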